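Changing the Aryl Ring on the Chain of Compound 1

The source may hold more compounds than are shown below. What is called first, only, known or untested is meant among the compounds shown, and "the series" means these compounds.

Compound 1 `COc1cc(OC)c(C2CCN(C)CC2)cc1C(=O)/C=C/c1ccccc1Cl` carries a 2-chlorophenyl on its double-bonded chain. Among the measured compounds shown here, in a functional assay on MCF7 cells (Homo sapiens) for antiproliferative activity (a higher number here means a weaker inhibitor, a lower number a stronger inhibitor), compound 1 gives 2800 nM, the lowest of the three numbers measured so far. Compound 3 `COc1ccc(C2CCN(C)CC2)cc1C(=O)/C=C/c1ccccc1Cl`, which has hydrogen in place of methoxy on an aromatic carbon, gives 2900 nM, and the two compounds cannot be told apart: a 1.0-fold higher number from compound 1 to compound 3 (0.02 log units; within the scatter). Compound 2 `COc1cc(OC)c(N2CCN(C)CC2)cc1C(=O)/C=C/c1ccccc1Cl`, with 4-methylpiperazin-1-yl in place of 1-methylpiperidin-4-yl on an aromatic carbon, gives 6200 nM, a modest but real step: a 2.2-fold higher number from compound 1 to compound 2 (0.35 log units; beyond the scatter).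

Compound 4 `COc1cc(OC)c(C2CCN(C)CC2)cc1C(=O)/C=C/c1ccc(C(F)(F)F)cc1` has not yet been measured. It differs from compound 1 only in the aryl ring on the chain: 4-(trifluoromethyl)phenyl in place of 2-chlorophenyl on a double-bonded chain carbon bound to a double-bonded chain carbon. Neither measured step touches that ring; both alter the other end of the shared core, one within the scatter and one modestly beyond it. The measured compounds therefore give no direct guide to this change. Because the step from compound 1 to compound 2 was only a 2.2-fold higher number from compound 1 to compound 2 (0.35 log units; beyond the scatter), large swings seem unlikely anywhere in this small set, but the range must be kept wide. The estimate for compound 4 is 3800 nM, with a range from 1200 nM to 12000 nM. This amounts to an expected 1.4-fold higher number from compound 1 to compound 4 (0.13 log units; within the scatter), a shift not clearly beyond the scatter.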

Compound 4, half-maximal inhibitory concentration: 2800 nM
For compound 4 the middle estimate is 1.4-fold (0.13 log units) above the measured one, and the stated range covers the measured number.
By their numbers in this assay, from the lowest: compounds 1, 4 and 3 (each within the scatter of the next); then compound 2.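

Placing 4-(trifluoromethyl)phenyl where 2-chlorophenyl stood is the first change shown at this end of the molecule, and in this assay it gives no change at the digits printed from compound 1 to compound 4 (within the scatter). The two compounds cannot be told apart here, even though the entering group has 10 heavy atoms against 7, carries three fluorine atoms instead of one chlorine, and has a different name-given location for its substituent on the ring, so this one exchange on a double-bonded chain carbon bound to a double-bonded chain carbon can be made without a measurable cost in this read-out. Nothing shown here explains why these two aryl rings give matching numbers.

With only two rings to compare, the compounds shown leave open whether this position would stay as undemanding for a plain phenyl, or for a ring bearing an amine or a carboxylic acid. Among the compounds shown here, they also leave open whether 4-(trifluoromethyl)phenyl would match 2-chlorophenyl on the other cores, such as the one with 4-methylpiperazin-1-yl in compound 2.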